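Exchanging the ring on the chain of compound 1

The compounds below may be only part of what the source reports. "The series", "measured", "known", "first", "only" and "open" are said of these compounds alone.

Compound 1 `COC1=C(C)C(=O)/C(=C(O)/C=C/c2ccc(Br)cc2)C(=O)C1(C)C` carries a 4-bromophenyl group on a double-bonded chain carbon bound to a double-bonded chain carbon. In a functional assay on PC-3 cells (Homo sapiens) for cytotoxicity (a higher number here means that more compound is needed for the effect, a lower number that less compound is needed), compound 1 gives 17.7 ug/mL. Compound 2 `COC1=C(C)C(=O)/C(=C(O)/C=C/c2ccccc2OC)C(=O)C1(C)C`, which carries a 2-methoxyphenyl group at that place, gives 15.6 ug/mL in this assay, and compound 3 `COC1=C(C)C(=O)/C(=C(O)/C=C/c2cccs2)C(=O)C1(C)C`, with thiophen-2-yl there, gives 18.2 ug/mL. Among these three numbers compound 1 stands second highest; its nearest is compound 3 and its furthest is compound 2, and both gaps lie within the scatter. The steps read a 1.1-fold lower number from compound 1 to compound 2 (0.05 log units; within the scatter) and a 1.0-fold higher number from compound 1 to compound 3 (0.01 log units; within the scatter), and between the other two compounds a 1.2-fold higher number from compound 2 to compound 3 (0.07 log units; within the scatter); none of the three exchanges of the ring at this place moved the number beyond the scatter.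

Compound 4 `COC1=C(C)C(=O)/C(=C(O)/C=C/c2nccs2)C(=O)C1(C)C` differs from compound 1 in one place: 1,3-thiazol-2-yl in place of 4-bromophenyl on a double-bonded chain carbon bound to a double-bonded chain carbon. The exchanges already measured at this place, including the one that brought in the five-membered thiophen-2-yl ring in compound 3 with a 1.0-fold higher number from compound 1 to compound 3 (0.01 log units; within the scatter), all stayed within the scatter, so the step in this assay meant by the estimate, a 1.0-fold lower number from compound 1 to compound 4 (0.02 log units; within the scatter), is expected to stay within the scatter as well, in no particular direction. On that basis compound 4 is estimated to give 17 ug/mL in this assay, with a range from 9 ug/mL to 32 ug/mL.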

Compound 4, concentration for half-maximal effect: 10.8 ug/mL
Beside the measured number, compound 4's estimate is 1.6-fold (0.20 log units) above it; the range from low to high includes it.
By their numbers in this assay, from the lowest: compounds 4, 2, 1 and 3 (each within the scatter of the next).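

In this assay, compound 4 places a five-membered aromatic ring with 2 hetero atoms and 2 hydrogen-bond acceptors on a double-bonded chain carbon bound to a double-bonded chain carbon, where the 4-bromophenyl group of compound 1 has no hydrogen-bond acceptors, yet the step stays within the scatter (a 1.6-fold lower number from compound 1 to compound 4 (0.21 log units; within the scatter)). The exchanges of thiophen-2-yl and of 2-methoxyphenyl for 1,3-thiazol-2-yl also stay within the scatter (a 1.7-fold lower number from compound 3 to compound 4 (0.23 log units; within the scatter)) and (a 1.4-fold lower number from compound 2 to compound 4 (0.16 log units; within the scatter)), so all four aromatic rings at this place, five-membered and six-membered alike, give numbers that this assay cannot tell apart. No measurement at hand bears on why these numbers lie so close together.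

The compounds leave open whether a group other than an aromatic ring at this place, such as an amine, a carboxylic acid or a longer alkyl chain, would move the number beyond the scatter in this assay. They also leave open how far the number depends on the shared core, which is the same in all four compounds.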